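From Carbamoylmethyl to Carbamoyl in the Tail Flick Test

The compounds below may be only part of what the source reports. "The series", "measured", "known", "first", "only" and "open" are said of these compounds alone.

Measured so far:
compound 1, `NC(=O)CC[C@H](NC(=O)CN(c1ncnc2c1ncn2C1CCCCO1)C1CC1)C(=O)OCc1ccccc1`, 37.8%
compound 2, `N=C(N)NCCC[C@H](NC(=O)CN(c1nc(Cl)nc2[nH]cnc12)C1CC1)C(=O)O`, 27.6%

Of the compounds shown here, two have been measured in a functional assay on the whole organism (Tail, strain ICR) with Mus musculus as the target, in the tail flick test, with a stated time of 90 min, at a dose of 25 umol/kg by the oral route; a higher number here means a stronger effect of the compound at the dose given, a lower number a weaker effect. Compound 1 gives 37.8%. Compound 2 gives 27.6%. Of these two numbers, compound 1 stands highest; compound 2 lies below it by a gap that is beyond the usual scatter of such measurements. The two compounds differ in more than one place, so what their two values show is only a difference in activity between them, not a step that can be tied to a single change.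

Compound 3, `NC(=O)C[C@H](NC(=O)CN(c1ncnc2c1ncn2C1CCCCO1)C1CC1)C(=O)OCc1ccccc1`, has not yet been measured. It differs from compound 1 in one place: carbamoyl in place of carbamoylmethyl on a saturated chain carbon, two bonds along the chain from an amide-type nitrogen and a carbonyl carbon. Among the compounds with values here, no measured pair in this set carries a comparable change, so no step size can be read from the data. The expected step of a number 4.8 percentage points lower from compound 1 to compound 3 (within the scatter) is therefore modest, most likely downward or within the scatter, taking the value of compound 1, 37.8%, as the only anchor. Compound 3 is estimated at 33%, with a range from 18% to 48%.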

Compound 3, a percentage reported as activity, at one dose (the size of the read-out at that dose, not a potency): 35%
The estimate for compound 3 lay 2 percentage points below the measured number; low and high end bracket the measured number.
By their numbers in this assay, from the lowest: compounds 2, 3 and 1 (each within the scatter of the next, the first and the last beyond it).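

In this assay, putting carbamoyl in place of carbamoylmethyl on a saturated chain carbon, two bonds along the chain from an amide-type nitrogen and a carbonyl carbon, gives a number 2.8 percentage points lower from compound 1 to compound 3 (within the scatter). Within the data shown here, this is the first step that can be tied to a single change, which the comparison of compound 1 with compound 2 could not provide, and it shows that at this one dose and time the two groups cannot be told apart at this position. No evidence on the cause of this result is available, and the step itself shows only its size.

What the compounds shown leave open is how far this position accepts other groups: a carboxylic acid, an amine or a longer chain in place of carbamoyl could each give a value beyond the scatter of compound 1, and the step from carbamoylmethyl to carbamoyl does not predict any of them. Also open, on these data alone, is whether the same holds at other doses and times, since a single read-out at one dose is not a potency.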